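From Chloro to Methoxy on Compound 2

The source may hold more compounds than are shown below. What is called first, only, known or untested is meant among the compounds shown, and "the series" means these compounds.

Compound 1 `Nc1ncnc2c1ncn2C[C@@H]1C[C@H](O)c2ccccc21` reaches only a limit in an ADME assay on L1210/0 cells (Mus musculus) for cytotoxicity, with a stated time of 48 h (on this read-out lower numbers stand for stronger inhibition and higher numbers for weaker inhibition), at > 200000 nM. Among the measured compounds shown here, compound 2 `OC[C@H]1C[C@@H](Cn2cnc3c(-c4ccc(Cl)cc4)ncnc32)c2ccccc21` gives 8440 nM, which makes it the only true number available so far and the natural starting point for comparison. Compound 3 `COc1ccc(-c2ncnc3c2ncn3C[C@@H]2C[C@H](CO)c3ccccc32)cc1` differs from compound 2 at one place, where the 4-chlorophenyl group becomes 4-methoxyphenyl: methoxy in place of chloro on an aromatic carbon. This puts methoxy in place of chloro on an aromatic carbon, para to a large group. For the measured compounds named here, no measured pair shows what this swap does, so any forecast must stay cautious. A small shift towards weaker inhibition in this assay is expected, hardly beyond the usual scatter, and the estimated step of a 1.4-fold higher number from compound 2 to compound 3 (0.15 log units; within the scatter) reflects this. Compound 3 is expected at 12000 nM, with an estimated range of 4000 nM to 40000 nM.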

Compound 3, half-maximal inhibitory concentration: 17600 nM
The estimate for compound 3 lay 1.5-fold (0.17 log units) below the measured number; measured number inside the range.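

Among the compounds shown here, putting methoxy in place of chloro on the aromatic carbon gives a 2.1-fold higher number from compound 2 to compound 3 (0.32 log units; beyond the scatter) in this assay and is the first measured evidence that this position responds to a change of group. The step is modest, yet it lies beyond the usual scatter, so inhibition is weaker with 4-methoxyphenyl than with 4-chlorophenyl, and compound 3 gives a true number rather than a limit. Nothing measured here explains why the number moves in this direction.

A single swap cannot show whether other groups on the same carbon, such as fluoro, an amine or a carboxylic acid, would strengthen or weaken inhibition further. On these data alone, it also remains open whether a longer chain such as ethoxy would take the number further in the same direction as methoxy.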